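Amide to Urea on the Chloropropyl Side Chain

A few compounds are considered here, and "the series" means these few. Any claim that something is new, unique, unknown or untested is made for them only; others in the source may bear on it.

Measured compounds:
- Compound 1, `CC(=O)Nc1ccc(S(=O)(=O)Oc2ccccc2I)cc1`: 27000 nM in a functional assay on MCF7 cells (Homo sapiens) for antiproliferative activity, read by sulforhodamine B assay, with a stated time of 48 h; on this read-out higher numbers stand for weaker inhibition and lower numbers for stronger inhibition
- Compound 2, `CC(C)c1ccccc1OS(=O)(=O)c1ccc(NC(=O)CCCCl)cc1`: 5200 nM in this assay
- Compound 3, `O=C(CCCCl)Nc1ccc(S(=O)(=O)Oc2ccccc2I)cc1`: 6300 nM in this assay

Compound 3 holds the second highest of the three numbers. Its nearest neighbour is compound 2, and the step of a 1.2-fold higher number from compound 2 to compound 3 (0.08 log units; within the scatter) lies within the scatter. Its furthest neighbour is compound 1, and the step of a 4.3-fold lower number from compound 1 to compound 3 (0.63 log units; beyond the scatter) lies beyond it.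

Compound 4, `O=C(NCCCCl)Nc1ccc(S(=O)(=O)Oc2ccccc2I)cc1`, differs from compound 3 by (3-chloropropyl)amino in place of 3-chloropropyl on a carbonyl carbon. Neither measured step touches this kind of change: one adds chain length, the other swaps a ring substituent. With nothing directly comparable, the expected step in this assay is no change at the digits printed from compound 3 to compound 4 (within the scatter), none beyond the scatter. Compound 4 is therefore estimated at 6300 nM, in a range from 2500 nM to 16000 nM.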

Compound 4, half-maximal inhibitory concentration: 7600 nM
Estimate against measurement, compound 4: 1.2-fold (0.08 log units) below; measured number inside the range.
By their numbers in this assay, from the lowest: compounds 2, 3 and 4 (each within the scatter of the next); then compound 1.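

In this assay, replacing 3-chloropropyl with (3-chloropropyl)amino on the carbonyl carbon turns the amide into a urea and adds a hydrogen-bond donor, yet the number does not move beyond the scatter (a 1.2-fold higher number from compound 3 to compound 4 (0.08 log units; within the scatter)). The urea also stays clear of the methyl on that carbonyl carbon (a 3.6-fold lower number from compound 1 to compound 4 (0.55 log units; beyond the scatter)), so in this pair the gain seen with the chloro chain survives the change. No supporting measurement explains this result.

Going by these compounds, whether a urea holds with a longer chain, or with an amine in place of the chlorine, remains open. So does whether isopropyl in place of iodo behaves the same in a urea.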